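A few compounds are considered here, and "the series" means these few. Any claim that something is new, unique, unknown or untested is made for them only; others in the source may bear on it.

Working notes on the series. The core of compound 1 `C[Se]c1nc([Se]C)c2cccnc2n1` opens the set, and in a functional assay on HT-29 cells (Homo sapiens) for cytotoxicity, read by MTT assay, with a stated time of 72 h (a lower number here means a stronger inhibitor of growth, a higher number a weaker inhibitor of growth), compound 1 gives "not determined" (no result reported). Within the data shown here, compound 2 `[SeH]c1nc(NCc2ccccc2)c2cccnc2n1` in this assay gives 33100 nM, the only single number in the set. For compound 3 `CCCCC[Se]c1nc(NCc2ccccc2)c2ccccc2n1` this assay reports only a limit, > 100000 nM (the limit of > 100000 nM in this assay, at which 1 of the 3 values shown sits). Compound 4 `CSc1nc(NCc2ccccc2)c2cccnc2n1` is not yet measured and differs from compound 2 by a group of 2 heavy atoms (1 carbon, 1 sulfur; no ring) in place of one selenium atom, on an aromatic carbon. Among the measured compounds shown here, no step between measured compounds is available for this change. The expected step of a 1.2-fold higher number from compound 2 to compound 4 (0.08 log units; within the scatter) is small, with no shift beyond the scatter anticipated in either direction. Compound 4 is expected to give 40000 nM, with a range of 12000 nM to 100000 nM.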

Compound 4, concentration for total growth inhibition: > 100000 nM
Compound 4 ended at the assay's limit; the forecaster's own chance of this, stated with the estimate: 30%; middle value at least 2.5-fold (0.39 log units) away from the limit.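

On the aromatic carbon between two ring nitrogen atoms, methylsulfanyl in place of one selenium atom gives an at least 3.0-fold higher number from compound 2 to compound 4 (0.48 log units; beyond the scatter) in this assay. Among these compounds, this is the first step read at this position, and it lies beyond the scatter, which the earlier compounds could not show. Compound 4 reads only as a limit, so the step has no upper bound: the limit of > 100000 nM in this assay, at which 2 of the 4 values shown sit.

Still open, as far as these compounds go, is whether an amine or a longer sulfur chain at this position would keep any growth inhibition in this assay. The same holds for a methylselanyl group on the core of compound 2.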